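Side-chain exchange on the shared core: cytotoxicity notes

The source may hold more compounds than are shown below. What is called first, only, known or untested is meant among the compounds shown, and "the series" means these compounds.

Measured so far:
compound 1 `COc1cccc(CNCCCNc2ccnc3cc(Cc4cc(C)cc(C)c4)ccc23)c1O`: 2680 nM
compound 2 `COc1cccc(CNCCCNc2ccnc3cc(CCC(C)C)ccc23)c1O`: 5390 nM

In an ADME assay on HepG2 cells (Homo sapiens) for cytotoxicity, read by luminescence, CellTiter-Glo and ATP content, with a stated time of 72 h (a lower number here means that less compound is needed, a higher number that more compound is needed for the effect), compound 1 gives 2680 nM and compound 2 gives 5390 nM. Within the data shown here, the single measured step is a 2.0-fold higher number from compound 1 to compound 2 (0.30 log units; within the scatter). Among the measured compounds shown here, compound 2 thus holds the higher of the two numbers, but its only neighbour, compound 1, lies within the scatter, so no order between the two is claimed.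

Compound 3 `COc1cccc(CNCCCNc2ccnc3cc(Oc4cccc(N(C)C)c4)ccc23)c1O` has not yet been measured in this assay. Relative to compound 2 the change is 3-(dimethylamino)phenoxy in place of isopentyl on an aromatic carbon. For the measured compounds named here, the only step that bears on this position is the one from compound 1 to compound 2, in which the 3,5-dimethylphenyl was replaced by isobutyl without a step beyond the scatter. Going by the values given here, the 3-(dimethylamino)phenoxy group is of a different kind from both isopentyl and 3,5-dimethylphenyl, and no measured step covers such a group, so the expectation rests on the quiet behaviour of this position alone.

Compound 3 is therefore expected to show no step beyond the scatter, a 1.3-fold lower number from compound 2 to compound 3 (0.13 log units; within the scatter), in this assay. The estimate for compound 3 is 4000 nM, with a range from 1300 nM to 12000 nM.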

Compound 3, half-maximal effective concentration: 7300 nM
Beside the measured number, compound 3's estimate is 1.8-fold (0.26 log units) below it; the range from low to high includes it.
By their numbers in this assay, from the lowest: compounds 1, 2 and 3 (each within the scatter of the next, the first and the last beyond it).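

The new compound extends this position to an aryl ether: in this assay the exchange of isopentyl for 3-(dimethylamino)phenoxy on an aromatic carbon gives a 1.4-fold higher number from compound 2 to compound 3 (0.13 log units; within the scatter) and so stays quiet, despite the added aromatic ring and two hydrogen-bond acceptors. Among these compounds, measured against the 3,5-dimethylbenzyl group, the same entering group gives a 2.7-fold higher number from compound 1 to compound 3 (0.44 log units; beyond the scatter) as the first modest step at this position to pass the scatter, although compound 2 remains within the scatter of both other compounds, so the three do not separate into distinct levels. No measured evidence accounts for either step.

The compounds shown do not separate the contribution of the ether oxygen from that of the dimethylamino group, and an unsubstituted phenoxy group or a plain benzyl group on the same aromatic carbon would bear directly on that question. As far as these compounds go, it also remains open whether the quiet behaviour extends to a carboxylic acid, a primary amine or a longer alkyl chain at this position, since the present range covers only neutral carbon-rich side chains and one aryl ether.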